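Carboxymethoxy extension of compound 3 in the cyclopentenone series

The compounds below may be only part of what the source reports. "The series", "measured", "known", "first", "only" and "open" are said of these compounds alone.

Compound 1 `COc1ccc(C2=C(c3cc(OC)c(OC)c(OC)c3)CC(O)C2=O)cc1[N+](=O)[O-]` is the nitro member of the set. In an ADME assay on MIA PaCa-2 cells (Homo sapiens) for cytotoxicity, read by MTT assay, with a stated time of 72 h (on this read-out higher numbers stand for weaker inhibition and lower numbers for stronger inhibition), compound 1 gives only a limit of > 100 ug/mL. Compound 2 `COc1ccc(C2=C(c3cc(OC)c(OC)c(OC)c3)CC(O)C2=O)cc1N` carries the amine instead; in this assay compound 2 likewise gives only a limit of > 100 ug/mL. The step that the two limits leave unreadable from compound 1 to compound 2 is consequently of unknown size. Compound 3 `COc1ccc(C2=C(c3cc(OC)c(OC)c(OC)c3)C(=O)CC2O)cc1` lacks both groups; in this assay compound 3 also gives only a limit of > 100 ug/mL. Going by the values given here, every value shown sits at the limit of > 100 ug/mL in this assay, at which 3 of the 3 values shown sit, so no measured step in this set has a readable size or direction.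

Compound 4 `COc1cc(C2=C(c3ccc(OCC(=O)O)cc3)C(O)CC2=O)cc(OC)c1OC` is obtained from compound 3 by carboxy in place of hydrogen on a saturated chain carbon bound to an oxygen on an aromatic ring. Among the compounds with values here, no measured step concerns a change of this kind; the single step at hand, nitro to amine, is itself unreadable between two limits. With all three shown values resting at the limit of > 100 ug/mL in this assay, at which 3 of the 3 values shown sit, the expectation for the step of a number no higher from compound 3 to compound 4 (the limit leaves the size open) is no movement that could be read, and compound 4 is expected most likely to return a limit as well. Compound 4 is estimated at 100 ug/mL, within a range from 30 ug/mL to 300 ug/mL.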

Compound 4, half-maximal inhibitory concentration: > 100 ug/mL
Compound 4: a limit, no number; the forecaster's own chance of this, stated with the estimate: 75%; the middle value sits exactly at the limit.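

Going by these compounds alone, compound 4, like compound 3, returns only a limit, so no step between compound 3 and compound 4 can be read: the limit of > 100 ug/mL in this assay, at which 4 of the 4 values shown sit.

The compounds shown leave open whether carboxy in place of hydrogen, or any other change on the shared core, moves the read-out in this assay at all.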